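The compounds below may be only part of what the source reports. "The series", "measured", "known", "first", "only" and "open" are said of these compounds alone.

Compound 3 `C[C@@H]1CC(=O)C=C2CC[C@](O)(C(C)(O)CO)C[C@]21C` gives 290 ug/mL in a functional assay on A549 cells (Homo sapiens) for antiproliferative activity (on this read-out higher numbers stand for weaker inhibition and lower numbers for stronger inhibition), the highest number among the three recorded; compound 1 `C[C@@H]1CC(=O)C=C2CC[C@@H]([C@@]3(C)CO3)C[C@]21C` stands nearest with 167 ug/mL, within the scatter, while compound 2 `C=C(CO)[C@@H]1CCC2=CC(=O)C[C@@H](C)[C@]2(C)C1` lies furthest with 36 ug/mL. Going by the values given here, the only measured step, a 4.6-fold lower number from compound 1 to compound 2 (0.67 log units; beyond the scatter), concerns a different part of the shared core and does not bear on the change now considered. Compound 4 `C[C@@H]1CC(=O)C=C2CC[C@@H](C(C)(O)CO)C[C@]21C` differs from compound 3 by hydrogen in place of hydroxy on a saturated ring carbon. Among the compounds with values here, no measured step touches this position, so nothing in the data points to a shift in either direction. Compound 4 is therefore expected to give about 200 ug/mL, with a range from 70 ug/mL to 600 ug/mL. The expected step, a 1.5-fold lower number from compound 3 to compound 4 (0.16 log units; within the scatter), is estimated to stay within the scatter.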

Compound 4, concentration for 50% inhibition: 325 ug/mL
Compound 4: middle estimate off by 1.6-fold (0.21 log units), on the low side; low and high end bracket the measured number.
By their numbers in this assay, from the lowest: compound 2; then compounds 1, 3 and 4 (each within the scatter of the next).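

In this assay hydrogen and hydroxy on this saturated ring carbon cannot be told apart, since a 1.1-fold higher number from compound 3 to compound 4 (0.05 log units; within the scatter) stays within the scatter. Against the other side chains, a 1.9-fold higher number from compound 1 to compound 4 (0.29 log units; within the scatter) also stays within the scatter, while a 9.0-fold higher number from compound 2 to compound 4 (0.96 log units; beyond the scatter) lies beyond it, which leaves the 1-(hydroxymethyl)ethenyl group of compound 2 alone apart from the other three compounds. Nothing at hand explains this result.

On these data alone, whether an amine or a methoxy group on this ring carbon would read any differently remains open. So does whether a hydroxy here would matter alongside the 1-(hydroxymethyl)ethenyl group.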